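A Dinitrophenyl Swap Tested Against Normal Liver Cells

This account rests on a few compounds, and the source may have more. Where it says the series, first, only, none or still open, it means among the compounds named here.

Of the compounds shown here, three have been measured in an ADME assay on L02 cells (Homo sapiens) for antiproliferative activity, read by MTT assay, with a stated time of 48 h; on this read-out higher numbers stand for weaker inhibition and lower numbers for stronger inhibition. Compound 1 `COc1ccccc1-n1nncc1CN1C(=O)C2(C(C#N)=C(N)Oc3c2c2nc4ccccc4nc2c2ccccc32)c2ccccc21` reaches only the limit of the measurement, giving > 50000 nM. Compound 2 `Cc1ccc(-n2nncc2CN2C(=O)C3(C(C#N)=C(N)Oc4c3c3nc5ccccc5nc3c3ccccc43)c3ccccc32)cc1C` likewise stops at a limit, with > 50000 nM. Compound 3 `CCOc1ccc(-n2nncc2CN2C(=O)C3(C(C#N)=C(N)Oc4c(N)cc5nc6ccccc6nc5c43)c3ccccc32)cc1` also gives a limit, > 50000 nM. Among the compounds with values here, the one step between compounds that differ in a single place, a step that the two limits leave unreadable from compound 1 to compound 2, has no readable size. Compound 3 thus stands where every measured value stands, at the limit (the limit of > 50000 nM in this assay, at which 3 of the 3 values shown sit).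

Compound 4 `N#CC1=C(N)Oc2c(N)cc3nc4ccccc4nc3c2C12C(=O)N(Cc1cnnn1-c1ccc([N+](=O)[O-])cc1[N+](=O)[O-])c1ccccc12` arises from compound 3 by the change (2,4-dinitrophenyl in place of 4-ethoxyphenyl on an aromatic nitrogen). No measured step covers a change of this kind, and the one step that is shown gives no size. Within the data shown here, what has been seen is only that three different groups on the same aromatic nitrogen all leave inhibition of these cells too weak to measure. The expectation is that compound 4 also shows no step beyond the scatter, a number no higher from compound 3 to compound 4 (the limit leaves the size open), and most likely is again reported only as a limit. Compound 4 is estimated at 50000 nM, within 20000 nM to 100000 nM.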

Compound 4, half-maximal inhibitory concentration: 22800 nM
The estimate for compound 4 lay 2.2-fold (0.34 log units) above the measured number, and the stated range covers the measured number.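

In this assay, the group on the aromatic nitrogen can now be seen to move the read-out, since 2,4-dinitrophenyl in place of 4-ethoxyphenyl gives an at least 2.1-fold lower number from compound 3 to compound 4 (0.34 log units; beyond the scatter). Within the data shown here, the earlier compounds could not show this: the single step among them cannot be read, and each of the three gave only a limit, so a change at this place might have seemed to do nothing. Among these compounds, compound 4 is the first compound here with an actual number, which gives the series a reading against a background of limits: the limit of > 50000 nM in this assay, at which 3 of the 4 values shown sit.

The swap removes the ethoxy group and brings in two nitro groups at once, so the compounds shown do not tell whether one nitro group would give the same step, as a 4-nitrophenyl or a 2-nitrophenyl group would test, or whether an aminophenyl or a carboxyphenyl group on the same nitrogen would move the number at all. They also leave open whether 2,4-dinitrophenyl would lower the number on the core of compound 1, which differs from that of compound 4 in more than this one place.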